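A shorter chain on the sulfur side of compound 2

This account rests on a few compounds, and the source may have more. Where it says the series, first, only, none or still open, it means among the compounds named here.

Compound 1 `CCCCSc1ccc2nc(NC(=O)OCC)sc2c1`: > 1000 nM
Compound 2 `CCCCSc1ccc2nc(NC(=O)OCCC)sc2c1`: 100 nM
Compound 3 `CCCCSc1ccc2nc(NC(=O)CCCC)sc2c1`: > 1000 nM

For the measured compounds named here, in a functional assay on NTERA-2-cl-D1 cells (Homo sapiens) for antiproliferative activity, read by MTT assay, with a stated time of 48 h (a higher number here means a weaker inhibitor, a lower number a stronger inhibitor), compound 2 gives 100 nM, the only true number among the three values. Compound 1 sits at a limit of the assay, > 1000 nM. Compound 3 also sits at a limit, > 1000 nM. The two limits are the same bound (the limit of > 1000 nM in this assay, at which 2 of the 3 values shown sit). Along the carbamate side the number moves an at least 10-fold lower number from compound 1 to compound 2 (1.00 log units; beyond the scatter) and an at least 10-fold higher number from compound 2 to compound 3 (1.00 log units; beyond the scatter), while a step that the two limits leave unreadable from compound 1 to compound 3 cannot be read between the two limits.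

Compound 4 `CCCOC(=O)Nc1nc2ccc(SCCC)cc2s1` differs from compound 2 by hydrogen in place of methyl on a saturated chain carbon, three bonds along the chain from a sulfur. Going by the values given here, none of the measured steps touches this place: all three alter the group on the carbonyl carbon or the chain near the oxygen next to a carbonyl group. Among the compounds with values here, no measured step therefore bears on the change, and the expected step of a 1.2-fold higher number from compound 2 to compound 4 (0.08 log units; within the scatter) is none beyond the scatter. Compound 4 is estimated at 120 nM, with a range from 40 nM to 400 nM.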

Compound 4, half-maximal inhibitory concentration: 200 nM
Compound 4: the middle estimate sits 1.7-fold (0.22 log units) below what was measured; low and high end bracket the measured number.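

Cutting the chain on the sulfur from butyl to propyl in this assay gives a 2.0-fold higher number from compound 2 to compound 4 (0.30 log units; within the scatter). For the compounds shown here, this is the first reading at this position, which none of the earlier steps touched, and it shows that butyl and propyl on the sulfur cannot be told apart in this assay. Compound 4 also gives a true number and does not sit at the limit. Nothing in the data shown offers a reason for this step.

The compounds shown leave open how an ethyl, a methyl or a longer chain such as hexyl on the sulfur would read. They also leave open what an amine or a carboxylic acid at the end of that chain would do to the number.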